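The source may report more compounds than this note shows. Statements on the series, on what has been measured and on what is new or still open speak of the compounds shown alone.

Measured compounds:
Compound 1 `Cc1ccccc1-c1nc2cn(-c3cccc(C#N)c3)nc2c(=O)n1CC1CCCN(C(C)C)C1` gives 32 nM in an assay on HEK293 cells for displacement of a labelled ligand from growth hormone secretagogue receptor type 1 (Homo sapiens), with a stated time of 60 min; on this read-out lower numbers stand for stronger inhibition and higher numbers for weaker inhibition.
Compound 2 `CCO[C@@H](C)CN1CCC[C@H](Cn2c(-c3cccnc3C)nc3cn(-c4cccc(OC)c4)nc3c2=O)C1` gives 5 nM in this assay.

For the measured compounds named here, of the two numbers known, compound 1 stands at the higher one, so its binding is the weaker of the pair. Compound 2 reaches a number that is beyond the usual scatter below it, but compound 2 differs from compound 1 in several places at once, so no single one of those changes can be credited for the gap.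

Compound 3 `COc1ccc(-n2cc3nc(-c4ccccc4C)n(CC4CCCN(C(C)C)C4)c(=O)c3n2)cc1` is compound 1 with one change: 4-methoxyphenyl in place of 3-cyanophenyl on an aromatic nitrogen. Nothing measured here isolates this exact swap. Going by the values given here, the one other compound with a methoxyphenyl group on that nitrogen, compound 2, gives the lower number, but its other differences leave that hint weak. The step from compound 1 to compound 3 is therefore expected to be small, leaning toward a somewhat lower number, and possibly within the scatter: a 1.5-fold lower number from compound 1 to compound 3 (0.16 log units; within the scatter). Compound 3 is estimated at 22 nM in this assay, within a range from 7 nM to 70 nM.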

Compound 3, half-maximal inhibitory concentration: 7.3 nM
Compound 3: middle estimate off by 3.0-fold (0.48 log units), on the high side, and the stated range covers the measured number.
By their numbers in this assay, from the lowest: compounds 2 and 3 (each within the scatter of the next); then compound 1.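

Replacing 3-cyanophenyl with 4-methoxyphenyl on the aromatic nitrogen, with the rest of the molecule unchanged, gives a 4.4-fold lower number from compound 1 to compound 3 (0.64 log units; beyond the scatter) in this assay and so shows that the group on this nitrogen can move the number by more than the usual scatter. The change is not a matter of size or of simple counts: both groups have the same number of heavy atoms and hydrogen-bond acceptors, and both carry a six-membered aromatic ring of carbon only, yet a nitrile gives way to a methoxy group and the substituent's ring position differs. Nothing available here gives a measured reason for the lower number, so the step stands as an observation only.

This single step changes the substituent and its ring position together, so it remains open which of the two accounts for the shift, and a comparison with 4-cyanophenyl on the same nitrogen would help separate them. As far as these compounds go, it is also open how the number would respond to other groups at this position, such as plain phenyl, 4-ethoxyphenyl or 4-aminophenyl.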